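The compounds below may be only part of what the source reports. "The series", "measured", "known", "first", "only" and "open" are said of these compounds alone.

Compound 1 `COC(=O)[C@@]1(C)CCC=C2[C@@H]1CC[C@@H](C)[C@]2(C)Cc1c[nH]c2ccccc12` gives 5000 nM in a functional assay on A549 cells (Homo sapiens) for inhibition, read by sulforhodamine B assay, with a stated time of 48 h; a lower number here means a stronger inhibitor of growth, a higher number a weaker inhibitor of growth. Compound 2 `COC(=O)[C@@]1(C)CCC=C2[C@@H]1CC[C@@H](C)[C@]2(C)Cc1c[nH]c2ccc(C)cc12` gives 17000 nM, and compound 3 `COC(=O)[C@@]1(C)CCC=C2[C@@H]1CC[C@@H](C)[C@]2(C)Cc1c(C)[nH]c2ccccc12` gives 15000 nM. Compound 3 thus stands second highest of the three numbers: its value and that of compound 2 lie within the scatter of each other, while a 3.0-fold higher number from compound 1 to compound 3 (0.48 log units; beyond the scatter). Compound 4 `COC(=O)[C@@]1(C)CCC=C2[C@@H]1CC[C@@H](C)[C@]2(C)Cc1c(C)[nH]c2ccc(C)cc12` differs from compound 3 by methyl in place of hydrogen on an aromatic carbon. The step that bears on this directly is a 3.4-fold higher number from compound 1 to compound 2 (0.53 log units; beyond the scatter), the same methyl entering at the same place; it was modest but beyond the scatter. A modest upward step in this assay is therefore expected, a 2.7-fold higher number from compound 3 to compound 4 (0.43 log units; beyond the scatter). Compound 4 is estimated at 40000 nM, with a range from 15000 nM to 110000 nM.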

Compound 4, concentration for 50% growth inhibition: 26000 nM
Beside the measured number, compound 4's estimate is 1.5-fold (0.19 log units) above it; measured number inside the range.
By their numbers in this assay, from the lowest: compound 1; then compounds 3, 2 and 4 (each within the scatter of the next).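

On the core of compound 3, methyl in place of hydrogen on the six-membered aromatic ring gives a 1.7-fold higher number from compound 3 to compound 4 (0.24 log units; within the scatter), and the other methyl, on the core of compound 2, gives a 1.5-fold higher number from compound 2 to compound 4 (0.18 log units; within the scatter), so with both methyls present neither step stands clear of the scatter. The first step still agrees with its counterpart on the core of compound 1: the same change on two cores in this assay, a 3.4-fold higher number (0.53 log units; beyond the scatter) from compound 1 to compound 2 and a 1.7-fold higher number (0.24 log units; within the scatter) from compound 3 to compound 4, 2.0-fold (0.29 log units) apart, within the scatter of two such steps. The second does too: the same change on two cores in this assay, a 3.0-fold higher number (0.48 log units; beyond the scatter) from compound 1 to compound 3 and a 1.5-fold higher number (0.18 log units; within the scatter) from compound 2 to compound 4, 2.0-fold (0.29 log units) apart, within the scatter of two such steps.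

From the compounds shown here alone, whether any group at this position gives a lower number than hydrogen stays open. A methoxy, a chlorine or a carboxylic acid on this aromatic carbon would test that.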